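Replacing the 3-methyl-1,2-oxazol-4-yl group of compound 2

The source may report more compounds than this note shows. Statements on the series, on what has been measured and on what is new or still open speak of the compounds shown alone.

Measured in an ADME assay on microsomes from liver (Homo sapiens) for metabolic stability, with a stated time of 10 min, tested at 0.5 uM; a lower number here means that less of the compound is left, a higher number that more of the compound is left:
- compound 1 `Cc1noc(C)c1[C@@H]1C[C@@](C)(c2ccc(F)cc2F)N=C(N)S1`: 24%
- compound 2 `Cc1nocc1[C@@H]1C[C@@](C)(c2ccc(F)cc2F)N=C(N)S1`: 65%

Of the two measured compounds, compound 2 stands higher in this assay, at 65%. Next in the series is compound 3 `Cn1nccc1[C@@H]1C[C@@](C)(c2ccc(F)cc2F)N=C(N)S1`, which carries 1-methyl-1H-pyrazol-5-yl in place of 3-methyl-1,2-oxazol-4-yl on a saturated ring carbon.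

Going by the values given here, the only measured step nearby is a number 41 percentage points higher from compound 1 to compound 2 (beyond the scatter), a large step beyond the scatter, from hydrogen in place of methyl on an aromatic carbon. It is a different change from this swap of whole groups, so it gives no direct size or direction, only a sign that this read-out can move widely with small edits to this group. A slight fall, not clearly beyond the scatter, is the working expectation.

The expected step is a number 10 percentage points lower from compound 2 to compound 3 (within the scatter). For compound 3 the estimated value is 55%, with an expected range of 30% to 78%.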

Compound 3, percent of the compound remaining: 70%
Beside the measured number, compound 3's estimate is 15 percentage points below it; measured number inside the range.
By their numbers in this assay, from the lowest: compound 1; then compounds 2 and 3 (each within the scatter of the next).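

At this saturated ring carbon, next to the ring sulfur, 1-methyl-1H-pyrazol-5-yl and 3-methyl-1,2-oxazol-4-yl cannot be told apart in this assay (swap: a number 5 percentage points higher from compound 2 to compound 3 (within the scatter)). Against 3,5-dimethyl-1,2-oxazol-4-yl, the same pyrazole gives a much larger step (a number 46 percentage points higher from compound 1 to compound 3 (beyond the scatter)), so compound 2 is no longer the only compound at this level: a second five-membered aromatic ring with a different set of hetero atoms also stands well clear of compound 1. Nothing available here explains why these two rings read alike or why compound 1 stands apart.

From the compounds shown here alone, whether the methyl group on the pyrazole matters remains open, since the series holds no pyrazole without it. Also open, going by these compounds, is whether a phenyl ring or an amine at this carbon would stay at this level.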